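The source may report more compounds than this note shows. Statements on the series, on what has been measured and on what is new or still open speak of the compounds shown alone.

Working notes on a small set built on the shared core of compound 1 `NC(C(=O)O)c1cnn(O)c1Br`. In a functional assay on CHO cells for agonist activity at metabotropic glutamate receptor 2 (Rattus norvegicus), read by cAMP accumulation (on this read-out lower numbers stand for an effect already at smaller amounts and higher numbers for an effect only at larger amounts of compound), compound 1 gives 170000 nM; 151000 nM (2 entries), the two entries lying within the usual scatter of each other. Compound 2 `CCCCCc1c(C(N)C(=O)O)cnn1O` carries the pentyl chain. In this assay compound 2 returns only a limit, > 1000000 nM, not a number. Compound 2 thus stands at the limit of > 1000000 nM in this assay, at which 1 of the 2 values shown sits, with a further entry that also gives no single number, so compound 2 can only be placed beyond the range in which compound 1 was read.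

Compound 3 `NC(C(=O)O)c1cnn(O)c1CC1CC1` has not yet been measured. It differs from compound 2 by cyclopropyl in place of butyl on a saturated chain carbon bound to an aromatic carbon. Going by the values given here, no step between measured compounds covers this change, so its size rests on expectation alone. The step from compound 2 to compound 3 in this assay is expected to be an at least 2.0-fold lower number from compound 2 to compound 3 (0.30 log units; that floor lies within the scatter), a move of modest size towards smaller amounts, though a second limit remains quite possible. In this assay compound 3 is expected to give 500000 nM, within a range from 150000 nM to 2000000 nM.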

Compound 3, half-maximal effective concentration: > 1000000 nM
Compound 3: only a limit was reported; the forecaster's own chance of this, stated with the estimate: 50%; at least 2.0-fold (0.30 log units) between middle value and limit.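

In this assay compound 3 gives only a limit, > 1000000 nM. Compound 2 likewise stands at a limit, so no step can be read between compound 2 and compound 3. The compounds shown leave open whether cyclopropyl in place of butyl on a saturated chain carbon bound to an aromatic carbon shifts the read-out in either direction.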